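The compounds below may be only part of what the source reports. "The series", "measured", "known", "first", "only" and "open" are said of these compounds alone.

Of the compounds shown here, three built on one shared core have been measured in an assay on HT-29 cells for inhibition of Serine-protein kinase ATM (Homo sapiens), read by fluorescence, with a stated time of 1 h; on this read-out higher numbers stand for weaker inhibition and lower numbers for stronger inhibition. Compound 1 `CCC(CC)CNc1c(C(N)=O)cnc2ccc(-c3cccnc3)cc12` gives 73 nM. Compound 2 `CCC(CC)CNc1c(C(N)=O)cnc2ccc(-c3ccc(COC)cc3)cc12` gives 373 nM. Compound 3 `CCC(CC)CNc1c(C(N)=O)cnc2ccc(-c3cncnc3)cc12` gives 1840 nM, the highest number of the three and therefore the weakest inhibitor among them: it stands a 4.9-fold higher number from compound 2 to compound 3 (0.69 log units; beyond the scatter) and a 25-fold higher number from compound 1 to compound 3 (1.40 log units; beyond the scatter).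

Compound 4 `CCC(CC)CNc1c(C(N)=O)cnc2ccc(-c3ccc(C)nc3)cc12` has not yet been measured. It differs from compound 3 in one place: 6-methylpyridin-3-yl in place of pyrimidin-5-yl on an aromatic carbon. Among the measured compounds shown here, two measured steps bear on this change. Swapping pyridin-3-yl for pyrimidin-5-yl gave a 25-fold higher number from compound 1 to compound 3 (1.40 log units; beyond the scatter); compound 4 reverses that exchange while also carrying a methyl group, for which no measured comparison exists. The step of a 5.1-fold higher number from compound 1 to compound 2 (0.71 log units; beyond the scatter) shows that another exchange at the same place moved the number by a smaller amount. The expectation is therefore a large drop in the number from compound 3 to compound 4, back toward compound 1, estimated as a 17-fold lower number from compound 3 to compound 4 (1.22 log units; beyond the scatter). The methyl group remains the unknown part, so the range is kept wide. Compound 4 is expected to give about 110 nM in this assay, within a range from 35 nM to 400 nM.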

Compound 4, half-maximal inhibitory concentration: 50 nM
Compound 4: the middle estimate sits 2.2-fold (0.34 log units) above what was measured, within the range that was stated.
By their numbers in this assay, from the lowest: compounds 4 and 1 (each within the scatter of the next); then compound 2; then compound 3.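

In this assay, the methyl group that was the unknown part leaves no detectable mark: methyl in place of hydrogen gives a 1.5-fold lower number from compound 1 to compound 4 (0.16 log units; within the scatter) and so compound 1 and compound 4 cannot be told apart in this assay. This means that the ring at this position can carry a methyl group without losing what pyridin-3-yl provides, and the exchange of pyrimidin-5-yl for 6-methylpyridin-3-yl gives a 37-fold lower number from compound 3 to compound 4 (1.57 log units; beyond the scatter) as a large step. A substituent on the ring therefore does not by itself set the number, since 6-methylpyridin-3-yl in place of 4-(methoxymethyl)phenyl gives a 7.5-fold lower number from compound 2 to compound 4 (0.87 log units; beyond the scatter) even though both groups carry one, but that exchange alters the ring and its substituent together, so their separate shares cannot be read.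

Going by these compounds, it remains open whether an ethyl, a methoxy or an amine in the place of this methyl group would be tolerated equally well. Also open, on these data alone, is how a 4-methylphenyl ring would compare, which would test the ring nitrogen with the methyl group kept. Nothing available here accounts for why any of these exchanges moves the number.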